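The source may hold more compounds than are shown below. What is called first, only, known or untested is meant among the compounds shown, and "the series" means these compounds.

Values in a functional assay on MC-38 cells (Mus musculus) for antiproliferative activity; on this read-out higher numbers stand for weaker inhibition and lower numbers for stronger inhibition:
Compound 1 `N#Cc1ccc(S(=O)(=O)Nc2cccc3c(C#N)c[nH]c23)cc1`: 0.12 ug/mL
Compound 2 `N#Cc1c[nH]c2c(NS(=O)(=O)c3ccc(C(=O)O)cc3)cccc12`: > 100 ug/mL, a limit of the assay and not a number
Compound 3 `N#Cc1c[nH]c2c(NS(=O)(=O)c3ccc(C(N)=O)cc3)cccc12`: 0.68 ug/mL

Of the two true numbers, compound 3 has the higher one, and the gap is modest: a 5.7-fold higher number from compound 1 to compound 3 (0.75 log units; beyond the scatter). The unmeasured compound 4 `CS(=O)(=O)Nc1ccc(S(=O)(=O)Nc2cccc3c(C#N)c[nH]c23)cc1` carries methanesulfonamido in place of carbamoyl on an aromatic carbon, para to a large group (methanesulfonamido in place of carbamoyl on an aromatic carbon). Within the data shown here, no measured compound carries this group, so the evidence is only indirect. The measured steps all change this same place, and their sizes differ widely. Beside the modest step above stand two large ones, an at least 830-fold higher number from compound 1 to compound 2 (2.92 log units; beyond the scatter) and an at least 140-fold lower number from compound 2 to compound 3 (2.16 log units; beyond the scatter), both of which involve the limit of compound 2. This place can therefore matter a great deal, so the range must be wide. The expectation still follows the modest step, with compound 3 as the starting point at 0.68 ug/mL. The expected change, close to the scatter and leaning towards a higher number, is a 1.5-fold higher number from compound 3 to compound 4 (0.17 log units; within the scatter). For compound 4 the estimated value is 1 ug/mL, with an expected range of 0.15 ug/mL to 8 ug/mL.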

Compound 4, half-maximal inhibitory concentration: 1.2 ug/mL
Beside the measured number, compound 4's estimate is 1.2-fold (0.08 log units) below it, within the range that was stated.
By their numbers in this assay, from the lowest: compound 1; then compounds 3 and 4 (each within the scatter of the next). At a limit, above all of these: compound 2.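

In this assay, methanesulfonamido in place of carbamoyl on this aromatic carbon stays within the scatter, a 1.8-fold higher number from compound 3 to compound 4 (0.25 log units; within the scatter), so this larger group with no net charge fits here as well as the amide does, yet the nitrile of compound 1 remains clearly apart, a 10-fold higher number from compound 1 to compound 4 (1.00 log units; beyond the scatter). Among these compounds, the carboxylic acid of compound 2 stays far away from this new group, an at least 83-fold lower number from compound 2 to compound 4 (1.92 log units; beyond the scatter), so only that one group stands out by a large step. Compound 2 gives a limit and not a number: the limit of > 100 ug/mL in this assay, at which 1 of the 4 values shown sits.

On these data alone, whether an amine, a methyl ester or a longer sulfonamide chain on this carbon would come as close as the nitrile of compound 1 stays open. The compounds shown also give no reason for any of these differences.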